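Removing a nitro group from compound 2: what to expect

The compounds below may be only part of what the source reports. "The series", "measured", "known", "first", "only" and "open" are said of these compounds alone.

Measured compounds:
compound 1, `CCC(C)C(C(=O)Nc1ccc(C(C)=O)cc1)N(C(=O)c1ccccc1)S(=O)(=O)c1ccc([N+](=O)[O-])cc1`, 42.1%
compound 2, `CC(=O)c1ccc(NC(=O)C2CCCN2S(=O)(=O)c2ccc([N+](=O)[O-])cc2)cc1`, 24.3%
compound 3, `CC(=O)c1ccc(NC(=O)CN(C(=O)c2ccccc2)S(=O)(=O)c2ccccc2)cc1`, 40.7%

In a functional assay for inhibition, read by spectrophotometry, with a stated time of 20 min, tested at 3 mg/mL (a higher number here means a stronger effect of the compound at the concentration tested, a lower number a weaker effect), compound 2 gives 24.3%, the lowest of the three numbers. Its nearest neighbour in this assay is compound 3 with 40.7%, a gap that lies beyond the usual scatter, and the furthest is compound 1 with 42.1%, also beyond the scatter. No two of the measured compounds differ in only one place, so no single structural change can be read directly from these three values.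

The unmeasured compound 4, `CC(=O)c1ccc(NC(=O)C2CCCN2S(=O)(=O)c2ccccc2)cc1`, differs from compound 2 in one place: hydrogen in place of nitro on an aromatic carbon. Compound 1 carries the nitro group and compound 3 does not, yet both give numbers close to each other; but they differ elsewhere as well, so this offers no clean guide. With nothing else to rest on, the step from compound 2 to compound 4 is expected to stay within the scatter, a number 0.3 percentage points lower from compound 2 to compound 4 (within the scatter), in no particular direction. Compound 4 is therefore estimated to give about 24% in this assay, with a likely range from 10% to 40%.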

Compound 4, a percentage reported as inhibition, at one concentration (the size of the read-out at that concentration, not a potency): 29.2%
Compound 4: middle estimate off by 5.2 percentage points, on the low side; measured number inside the range.
By their numbers in this assay, from the lowest: compounds 2 and 4 (each within the scatter of the next); then compounds 3 and 1 (each within the scatter of the next).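

In this assay, putting hydrogen in place of nitro on an aromatic carbon, para to a large group, gives a number 4.9 percentage points higher from compound 2 to compound 4 (within the scatter). Going by these compounds alone, this is the first pair that differs in one place, so it gives the first direct reading of this position: on this core, compound 2 and compound 4 cannot be told apart, and the 4-nitrophenyl and the phenyl serve equally at the one concentration tested. No accompanying measurement bears on why the two numbers stand so close.

The compounds shown carry only nitro or hydrogen at this position, so what an amine, a carboxylic acid or a methoxy group on the same aromatic carbon would give remains open. Going by these compounds, whether 4-nitrophenyl to phenyl gives a similar step on the core of compound 1 also remains open, as do all other comparisons among the compounds, which differ in more than one place and cannot be read as single steps.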